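The source may hold more compounds than are shown below. What is called first, only, known or untested is meant among the compounds shown, and "the series" means these compounds.

Measured in a functional assay on KB cells (Homo sapiens) for inhibition; on this read-out higher numbers stand for weaker inhibition and lower numbers for stronger inhibition:
Compound 1 `COCCOCN1c2ncnc(N)c2C(C(=N)S)C1N`: > 320000 nM (a limit)
Compound 2 `N#Cc1c(N)n(COCc2ccccc2)c2ncnc(N)c12`: 118000 nM
Compound 3 `N#Cc1c(Br)n(COCc2ccccc2)c2ncnc(N)c12`: > 100000 nM (a limit)

Compound 3 has no exact number. Its > 100000 nM is a limit. Going by the values given here, compound 2 is the only compound here with a true number, 118000 nM.

Compound 4 `COCCOCn1c(Br)c(C#N)c2c(N)ncnc21` has not yet been measured. It differs from compound 3 as follows: methoxymethyl in place of phenyl on a saturated chain carbon bound to an oxygen on a saturated carbon. This places methoxymethyl in place of phenyl on a saturated chain carbon bound to an oxygen on a saturated carbon, so benzyl becomes 2-methoxyethyl.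

Among the compounds with values here, the one measured step is a step that the limit leaves unreadable from compound 2 to compound 3. Within the data shown here, it concerns a different group, so no measured step shows the size of this change. Compound 1 also carries 2-methoxyethyl, on a different core, and its > 320000 nM is a limit as well. Inhibition in this assay is therefore expected to stay weak, with no clear move in either direction.

The expected step is a step that the limit leaves unreadable from compound 3 to compound 4. For compound 4 the estimate is 150000 nM, with an expected range of 70000 nM to 400000 nM.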

Compound 4, half-maximal inhibitory concentration: > 100000 nM
Compound 4: only a limit was reported; the forecaster's own chance of this, stated with the estimate: 70%; the middle value does not contradict the limit.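

Compound 3 and compound 4 each have only a limit in this assay, so no step can be read for the change from benzyl to 2-methoxyethyl. The compounds shown leave open whether either group gives stronger inhibition on the shared core.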